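A few compounds are considered here, and "the series" means these few. Any claim that something is new, unique, unknown or untested is made for them only; others in the source may bear on it.

Measured compounds:
- compound 1, `CC(C)C[C@@H](N)C(=O)Nc1cc2cc[nH]c(=O)c2cc1Cl`: 19 nM
- compound 2, `N[C@@H](C(=O)Nc1cc2cc[nH]c(=O)c2cc1Cl)C1CCCCC1`: 400 nM
- compound 3, `CC(C)(C)C[C@H](N)C(=O)Nc1cc2cc[nH]c(=O)c2cc1Cl`: 845 nM

All three were tested in an assay on isolated protein for inhibition of Rho-associated protein kinase 2 (Homo sapiens); on this read-out lower numbers stand for stronger inhibition and higher numbers for weaker inhibition. Compound 3 has the highest number of the three: compound 2 comes nearest, and compound 1 lies furthest away, as the step of a 44-fold higher number from compound 1 to compound 3 (1.65 log units; beyond the scatter) shows. Compound 4, `N[C@H](C(=O)Nc1cc2cc[nH]c(=O)c2cc1Cl)C1CCCCC1`, is not yet measured; it differs from compound 3 by cyclohexyl in place of neopentyl on a saturated chain carbon bound to an amine nitrogen and a carbonyl carbon, and it is the mirror image of compound 2. Among the compounds with values here, the one measured step that bears on this exchange is a 21-fold higher number from compound 1 to compound 2 (1.32 log units; beyond the scatter), where a cyclohexyl replaced an open branched chain on the same carbon and gave a large loss. The measured step of a 44-fold higher number from compound 1 to compound 3 (1.65 log units; beyond the scatter) shows how far the neopentyl chain already weakened the series. On this basis the step of a 1.8-fold higher number from compound 3 to compound 4 (0.25 log units; within the scatter) is expected to be a further loss, though compound 3 starts from a weak value, so the margin is wide. Compound 4 is therefore estimated at 1500 nM in this assay, with a range from 300 nM to 7000 nM.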

Compound 4, half-maximal inhibitory concentration: 20 nM
For compound 4 the middle estimate is 75-fold (1.88 log units) above the measured one, outside the stated range (below it).
By their numbers in this assay, from the lowest: compounds 1 and 4 (each within the scatter of the next); then compound 2; then compound 3.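

In this assay, the saturated chain carbon bound to an amine nitrogen and a carbonyl carbon proves sensitive to its configuration and not only to the group it carries: with cyclohexyl held fixed, the result is a 20-fold lower number from compound 2 to compound 4 (1.30 log units; beyond the scatter) on going from a stereocentre drawn R to one drawn S. This large gap can be assigned to the stereocentre alone because of one fact: the fact that compounds 2 and 4 differ only in the configuration as drawn. Cyclohexyl on this carbon is thus not a loss in itself, since the exchange for neopentyl gives a 42-fold lower number from compound 3 to compound 4 (1.63 log units; beyond the scatter) in this series.

The compounds shown leave open whether the mirror images of compound 1 and compound 3 would show a gap of similar size. They also leave open whether a cyclopentyl or a phenyl on this carbon would behave like cyclohexyl.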